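The source may report more compounds than this note shows. Statements on the series, on what has been measured and on what is new or still open speak of the compounds shown alone.

In a physicochemical assay for lipophilicity (on this read-out lower numbers stand for lower lipophilicity and higher numbers for higher lipophilicity), compound 1 `CC(C)(C)OC(=O)N[C@H]1CCCCC/C=C\[C@@H]2C[C@@]2(C(=O)NS(=O)(=O)C2CC2)NC(=O)[C@@H]2C[C@@H](OC(=O)N3CCc4ccccc4C3)CN2C1=O` gives 2.2 and compound 2 `CC(C)(C)OC(=O)N[C@H]1CCCCC/C=C\[C@@H]2C[C@@]2(C(=O)NS(=O)(=O)C2CC2)NC(=O)[C@@H]2C[C@@H](OC(=O)N3Cc4ccccc4C3)CN2C1=O` gives 2.4. Within the data shown here, these two numbers lie within the scatter of each other, so compound 2 stands level with the only other measured compound.

The next change keeps the rest of compound 2 and touches only the group on the sulfonyl sulfur. Compound 3 `CN(C)S(=O)(=O)NC(=O)[C@@]12C[C@H]1/C=C\CCCCC[C@H](NC(=O)OC(C)(C)C)C(=O)N1C[C@H](OC(=O)N3Cc4ccccc4C3)C[C@H]1C(=O)N2` carries dimethylamino in place of cyclopropyl on a sulfonyl sulfur.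

Among the measured compounds shown here, only one measured step is available, a number 0.20 log units higher from compound 1 to compound 2 (within the scatter). It sits on a carbonyl carbon, not on the sulfonyl sulfur, and exchanges different groups, so it bears on the new change only indirectly. For the measured compounds named here, no measurement yet covers a change at the sulfonyl sulfur, and a single pair gives no direction to rely on. A shift beyond the scatter in this assay is not expected. The expected step is a number 0.10 log units higher from compound 2 to compound 3 (within the scatter), an estimate that amounts to no real change. For compound 3 the estimated value is 2.5, with an expected range from 2 to 3.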

Compound 3, distribution coefficient: 2.5
Beside the measured number, compound 3's estimate shows no gap at the digits printed; the measured number falls inside the stated range.
By their numbers in this assay, from the lowest: compounds 1, 2 and 3 (each within the scatter of the next).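

Among these compounds, the first step at the sulfonyl sulfur, read in this assay, is a number 0.10 log units higher from compound 2 to compound 3 (within the scatter), so dimethylamino in place of cyclopropyl leaves compound 3 level with compound 2 within the scatter. Swapping a three-membered ring of carbon only for a group with no ring therefore does not separate the two compounds on this read-out, just as the exchange on the carbonyl carbon does not in a number 0.20 log units higher from compound 1 to compound 2 (within the scatter). No measured evidence is at hand that would explain this result.

Whether any group on the sulfonyl sulfur moves this read-out beyond the scatter remains open, as the two groups shown do not settle how a longer chain, a phenyl ring or a carboxylic acid-bearing chain would read there. Also open is whether dimethylamino in place of cyclopropyl reads the same when the group on the carbonyl carbon differs, as the exchange is shown only with the group of compound 2.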